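This account rests on a few compounds, and the source may have more. Where it says the series, first, only, none or still open, it means among the compounds named here.

Measured compounds:
compound 1 `CN(C)C(=O)/C=C1\CCc2ccc(F)cc21` with 100%
compound 2 `O=C(/C=C1\CCc2ccc(F)cc21)N1CCCC1` with 33%
compound 3 `O=C(/C=C1\CCc2cc(F)c(F)cc21)NC1CC1` with 50%

In a functional assay on the whole organism with Mus musculus as the target, at a dose of 100 mg/kg by the intraperitoneal route (on this read-out higher numbers stand for more inhibition at the one dose given (going by the name of the read-out) and lower numbers for less inhibition), compound 2 stands lowest of the three numbers. Compound 3 gives 50%, beyond the scatter above it, and compound 1 gives 100%, the highest of the set. Within the data shown here, the one single-point step that is measured runs a number 67 percentage points lower from compound 1 to compound 2 (beyond the scatter), and it is the only step that bears on the change considered here, since it likewise alters the group on the carbonyl carbon while the rest of the molecule stays fixed.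

Compound 4 `O=C(/C=C1\CCc2ccc(F)cc21)N1CCC1` has not yet been measured in this assay. The change from compound 2 is azetidin-1-yl in place of pyrrolidin-1-yl on a carbonyl carbon. Among the measured compounds shown here, the amide substituent has already been seen to move the read-out by a large amount, so a step beyond the scatter is plausible, but no measured pair shows the direction for a four-membered ring. A moderate rise toward the other two compounds is expected rather than a further fall. Compound 4 is estimated at 50%, within 20% to 85%. The expected step is a number 17 percentage points higher from compound 2 to compound 4 (beyond the scatter).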

Compound 4, a percentage reported as inhibition, in the whole organism at one dose (the size of the read-out at that dose, not a potency): 33%
The estimate for compound 4 lay 17 percentage points above the measured number, and the stated range covers the measured number.
By their numbers in this assay, from the lowest: compounds 2 and 4 (each within the scatter of the next); then compound 3; then compound 1.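

In this assay, replacing pyrrolidin-1-yl with azetidin-1-yl on the carbonyl carbon gives no change at the digits printed from compound 2 to compound 4 (within the scatter), so this change of ring size has no readable effect in this pair. Against the open-chain dimethylamino group, the azetidin-1-yl amide shows a number 67 percentage points lower from compound 1 to compound 4 (beyond the scatter), which means the large loss first seen with pyrrolidin-1-yl also appears with the four-membered ring. No measurement offered here accounts for the match between the two rings or for their gap from compound 1.

Still open, going by these compounds, is whether a larger ring such as piperidine or morpholine would stay with compound 2 and compound 4 in this read-out. Equally open, on these data alone, is whether an open-chain diethylamino group would keep the level of compound 1 at this position.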